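The source may report more compounds than this note shows. Statements on the series, on what has been measured and on what is new or still open speak of the compounds shown alone.

In a functional assay on OVCAR-4 cells (Homo sapiens) for inhibition (a higher number here means a weaker inhibitor of growth, a lower number a stronger inhibitor of growth), compound 1 (`Nc1ccc(-c2nc3cc(F)ccc3s2)cc1`) gives 13500 nM, compound 2 (`Cc1cc(-c2nc3cc(F)c(F)cc3s2)ccc1N`) gives 60300 nM and compound 3 (`Cc1cc(-c2nc3cccc(F)c3s2)ccc1N`) gives 7400 nM. Compound 3 therefore sits within the scatter of compound 1 and well under compound 2, a gap beyond the scatter. Compound 4 (`Cc1cc(-c2nc3ccccc3s2)ccc1N`) differs from compound 3 by hydrogen in place of fluoro on an aromatic carbon. Within the data shown here, no pair of measured compounds isolates this change, so the expectation rests only on the spread of the three values. The expected move is small, toward stronger growth inhibition and within the scatter: a 1.9-fold lower number from compound 3 to compound 4 (0.27 log units; within the scatter). For compound 4 the estimated value is 4000 nM, with an expected range of 400 nM to 30000 nM.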

Compound 4, concentration for 50% growth inhibition: 1100 nM
Beside the measured number, compound 4's estimate is 3.6-fold (0.56 log units) above it; low and high end bracket the measured number.
By their numbers in this assay, from the lowest: compound 4; then compounds 3 and 1 (each within the scatter of the next); then compound 2.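

Hydrogen in place of fluoro on this aromatic carbon, ortho to a fused ring and meta to a fused ring, gives the first comparison in the series that isolates one place: a 6.7-fold lower number from compound 3 to compound 4 (0.83 log units; beyond the scatter) in this assay. At this position, then, the fluoro compound is the weaker inhibitor of growth, by a step beyond the scatter. Nothing measured here accounts for the size of this step.

On these data alone, whether a chloro or a methoxy on the same carbon would give a number nearer compound 3 or compound 4 remains open. So does whether fluoro on the other aromatic carbons of the core carries a similar penalty.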